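A few compounds are considered here, and "the series" means these few. Any claim that something is new, unique, unknown or untested is made for them only; others in the source may bear on it.

Compound 1 `Cc1ccc(SCc2ccc(C(=O)Nc3ccccc3N)cc2)cc1`: 17.5%
Compound 2 `Nc1ccccc1NC(=O)c1ccc(CSc2ccc(Br)cc2)cc1`: 4.35%

Both compounds were tested in a functional assay on A-375 cells (Homo sapiens) for inhibition, read by CCK-8 assay, with a stated time of 72 h, tested at 2 uM; on this read-out higher numbers stand for more inhibition of growth at the one concentration tested and lower numbers for less inhibition of growth. There, compound 2 gives 4.35%, the lower of the two numbers, while compound 1 reaches 17.5%. Compound 3 `CC(C)(C)c1ccc(SCc2ccc(C(=O)Nc3ccccc3N)cc2)cc1` has not yet been measured. It keeps the core of compound 2 and changes one group: tert-butyl in place of bromo on an aromatic carbon. In words, this is tert-butyl in place of bromo on an aromatic carbon, para to a large group.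

Among the measured compounds shown here, only one measured step bears on this change. It is a number 13.2 percentage points lower from compound 1 to compound 2 (beyond the scatter), a modest step that swaps methyl for bromo at the same place. Read in reverse, it suggests that replacing bromo with a carbon-only group could raise the number, although no measured compound carries tert-butyl and that group is larger than methyl. A modest rise is therefore expected, with real uncertainty about its size. The expected change in this assay is a number 10.7 percentage points higher from compound 2 to compound 3 (beyond the scatter). Compound 3 is estimated at 15%, with an expected range from 3% to 35%.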

Compound 3, percent growth inhibition at one concentration: 2.13%
Compound 3: middle estimate off by 12.9 percentage points, on the high side; measured number outside the range, below it.
By their numbers in this assay, from the lowest: compounds 3 and 2 (each within the scatter of the next); then compound 1.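

In this assay, tert-butyl in place of bromo on this aromatic carbon, para to a large group, gives a number 2.2 percentage points lower from compound 2 to compound 3 (within the scatter), so compounds 2 and 3 cannot be told apart, although 4 heavy atoms enter where 1 leaves. Tert-butyl in place of methyl at the same place gives a number 15.4 percentage points lower from compound 1 to compound 3 (beyond the scatter), which shows that a carbon-only group here does not by itself keep the number of compound 1; among the three compounds, only compound 1 stands apart from the other two. No evidence at hand explains this result.

The compounds shown leave open whether an amine, a methoxy group or a carboxylic acid at this place would give a number near that of compound 1, at 17.5%, or near those of compounds 2 and 3. They also leave open whether an ethyl group or a longer chain here would stay with compound 1 or fall with the other two, which would tell whether methyl is a lone case among the carbon-only groups.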